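The source may report more compounds than this note shows. Statements on the series, on what has been measured and on what is new or still open speak of the compounds shown alone.

Measured compounds in a functional assay on COLO 205 cells (Homo sapiens) for antiproliferative activity, read by MTT assay; on this read-out lower numbers stand for stronger inhibition and higher numbers for weaker inhibition:

compound 1 , `C#CCN(c1ncccn1)c1nc2ccccc2s1`: compound 1 gives 12000 nM
compound 2 , `FC(F)(F)Sc1ccc(-c2cc(CN(c3ncccn3)c3nc4ccccc4s3)on2)cc1`: compound 2 gives 10100 nM
compound 3 , `FC(F)(F)Oc1ccc(-c2cc(CN(c3ncccn3)c3nc4ccccc4s3)on2)cc1`: compound 3 gives 5690 nM

Compound 3 carries the lowest number of the three in this assay. Its gap to compound 2 is within the scatter, so no order between the two can be read; only the gap to compound 1 is beyond it.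

Compound 4 , `COc1ccc(-c2cc(CN(c3ncccn3)c3nc4ccccc4s3)on2)cc1`, is not yet measured. Relative to compound 3 the change is methyl in place of trifluoromethyl on an oxygen on an aromatic ring. Going by the values given here, no measured step has this change. Among the compounds with values here, the only step at the same place is a 1.8-fold lower number from compound 2 to compound 3 (0.25 log units; within the scatter), which exchanged one fluorinated group for another and stayed within the scatter; the two compounds with a substituted phenyl on the shared core lie close together, and the exchange to methoxy is the first move away from a fluorinated group at that position, for which the set gives no direct guidance.

On that basis no step beyond the scatter is expected in this assay: for compound 4 the expected change from compound 3 is a 1.1-fold higher number from compound 3 to compound 4 (0.06 log units; within the scatter). The estimate for compound 4 in this assay is 6500 nM, with a range from 2500 nM to 17000 nM.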

Compound 4, half-maximal inhibitory concentration: 5040 nM
The estimate for compound 4 lay 1.3-fold (0.11 log units) above the measured number; the measured number falls inside the stated range.
By their numbers in this assay, from the lowest: compounds 4, 3, 2 and 1 (each within the scatter of the next, the first and the last beyond it).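

In this assay, the first move away from a fluorinated group at this place gives a 1.1-fold lower number from compound 3 to compound 4 (0.05 log units; within the scatter), so methyl in place of trifluoromethyl on an oxygen on an aromatic ring produces no change that can be read. The wider exchange, methoxy in place of (trifluoromethyl)sulfanyl on an aromatic carbon, gives a 2.0-fold lower number from compound 2 to compound 4 (0.30 log units; within the scatter), which also stays within the scatter; compound 2, compound 3 and compound 4 therefore show no readable order among themselves, and the fluorine atoms of compound 2 and compound 3 are not needed to hold the number in this range. No measurement is at hand that could explain this flat result.

Still open, on these data alone, is whether an amine, a carboxylic acid or a longer alkoxy chain in place of methoxy would give a step beyond the scatter in this assay. Also open, as far as these compounds go, is how a plain hydrogen at this place would compare with methoxy, which would show whether any substituent on this phenyl ring matters to the number.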